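The compounds below may be only part of what the source reports. "The series", "measured", "known", "first", "only" and "open" are said of these compounds alone.

In a functional assay on NB-4 cells (Homo sapiens) for cytotoxicity, read by CCK-8 assay, with a stated time of 24 h (a lower number here means a stronger inhibitor, a higher number a weaker inhibitor), compound 2 (`C=CC(=O)N1C(=O)CCSc2ccccc21`) gives the lower of the two numbers, 22400 nM, and compound 1 (`C=CC(=O)N1C(=O)CC(C)Sc2ccccc21`) gives 227000 nM. Compound 3 (`C=CC(=O)N1C(=O)CC(c2ccccc2Cl)Sc2ccccc21`) has 2-chlorophenyl in place of hydrogen on a saturated ring carbon, next to the ring sulfur: 2-chlorophenyl in place of hydrogen on a saturated ring carbon. Among the compounds with values here, only one measured step bears on this carbon: a 10-fold lower number from compound 1 to compound 2 (1.01 log units; beyond the scatter), large and beyond the scatter, with methyl on the higher side. A single methyl step is thin evidence for 2-chlorophenyl, so a higher number of similar or smaller size is expected in this assay, with wide uncertainty. The expected change is a 2.7-fold higher number from compound 2 to compound 3 (0.43 log units; beyond the scatter). For compound 3 the estimated value is 60000 nM, with an expected range of 10000 nM to 300000 nM.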

Compound 3, half-maximal inhibitory concentration: 33800 nM
Beside the measured number, compound 3's estimate is 1.8-fold (0.25 log units) above it; the range from low to high includes it.
By their numbers in this assay, from the lowest: compounds 2 and 3 (each within the scatter of the next); then compound 1.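

In this assay the saturated ring carbon next to the ring sulfur accepts 2-chlorophenyl with a 1.5-fold higher number from compound 2 to compound 3 (0.18 log units; within the scatter), so the loss seen with methyl does not extend to every group on this carbon. The two substituents also separate from each other, with a 6.7-fold lower number from compound 1 to compound 3 (0.83 log units; beyond the scatter). No evidence on hand accounts for this difference.

Still open, going by these compounds, is how phenyl without chlorine, an amine or a carboxylic acid would behave on this carbon. Every compound shown keeps the vinylcarbonyl group, so its contribution to the cytotoxicity also remains open.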